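From butoxy to ethoxy: trimming the chain of compound 2

The source may hold more compounds than are shown below. What is called first, only, known or untested is meant among the compounds shown, and "the series" means these compounds.

Two compounds have so far been measured in a functional assay on NCI-H1650 cells (Homo sapiens) for cytotoxicity, read by MTT assay, with a stated time of 48 h; on this read-out lower numbers stand for stronger inhibition and higher numbers for weaker inhibition:

Compound 1, `CN(C)CCNc1ccnc2cc(OCc3ccc(F)cc3)ccc12`: 780 nM
Compound 2, `CCCCOc1ccc2c(Cl)ccnc2c1`: 2570 nM

Compound 2 holds the highest of the two numbers in this assay. Its nearest neighbour is compound 1, whose number is lower by a gap that lies beyond the usual scatter; the two compounds differ in many places at once, so their values can only be set side by side, not read as a single step.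

Compound 3, `CCOc1ccc2c(Cl)ccnc2c1`, is compound 2 with a shorter chain: hydrogen in place of ethyl on a saturated chain carbon, two bonds along the chain from an oxygen on an aromatic ring. Among the measured compounds shown here, no pair of measured compounds shows a change of this kind, so there is no measured step to lean on. A change that removes two chain carbons and nothing else is, on experience, a small one; the expectation is a step toward a somewhat higher number, but one that may well stay within the scatter. The step from compound 2 to compound 3 is expected to be a 1.4-fold higher number from compound 2 to compound 3 (0.13 log units; within the scatter). Compound 3 is therefore estimated at 3500 nM, within a range from 1500 nM to 8500 nM.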

Compound 3, half-maximal inhibitory concentration: 3340 nM
For compound 3 the middle estimate is 1.0-fold (0.02 log units) above the measured one; measured number inside the range.
By their numbers in this assay, from the lowest: compound 1; then compounds 2 and 3 (each within the scatter of the next).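

Among the compounds shown here, compound 3 gives the first measured step of this kind: in this assay, hydrogen in place of ethyl on a saturated chain carbon, two bonds along the chain from an oxygen on an aromatic ring, comes to a 1.3-fold higher number from compound 2 to compound 3 (0.11 log units; within the scatter). As this step lies within the scatter, butoxy and ethoxy cannot be told apart on this read-out, so in this one pair the loss of 2 carbons leaves no clear mark on the number. Nothing measured here offers an explanation for this result.

As far as these compounds go, the pair covers only these two chains, so it remains open what a longer chain such as octyl, or a chain carrying an amine or a carboxylic acid, would do at the same place. From the compounds shown here alone, whether any such group would move the number beyond the scatter also remains open, and compound 1 cannot settle this, as it differs from compound 2 and compound 3 in many places at once.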